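The source may report more compounds than this note shows. Statements on the series, on what has been measured and on what is new or still open speak of the compounds shown alone.

Measured so far in a functional assay on DU-145 cells (Homo sapiens) for antiproliferative activity, read by MTT assay, with a stated time of 48 h; a lower number here means a stronger inhibitor, a higher number a weaker inhibitor:
compound 1 `C/C(=C\CC/C(C)=C/CC[C@@H]1[C@@]2(C)CCC(=O)C(C)(C)[C@H]2CC[C@@]1(C)O)CC/C=C(\C)C(=O)OCc1cn(-c2cccc(O)c2)nn1` gives 28400 nM.
compound 2 `C#CCOC(=O)/C(C)=C/CC/C(C)=C/CC/C(C)=C/CC[C@@H]1[C@@]2(C)CCC(=O)C(C)(C)[C@H]2CC[C@@]1(C)O` gives 46100 nM.
compound 3 `C/C(=C\CC/C(C)=C/CC[C@@H]1[C@@]2(C)CCC(=O)C(C)(C)[C@H]2CC[C@@]1(C)O)CC/C=C(\C)C(=O)OCc1cn(-c2ccc(F)cc2)nn1` gives > 150000 nM, which is a limit of this assay rather than a number (the limit of > 150000 nM in this assay, at which 1 of the 3 values shown sits).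

Compound 2 holds the highest of the two numbers, with compound 1 within the scatter of it (a 1.6-fold higher number from compound 1 to compound 2 (0.21 log units; within the scatter)). The new analogue, compound 4 `C/C(=C\CC/C(C)=C/CC[C@@H]1[C@@]2(C)CCC(=O)C(C)(C)[C@H]2CC[C@@]1(C)O)CC/C=C(\C)C(=O)OCc1cn(-c2ccccc2F)nn1`, differs from compound 2 by 1-(2-fluorophenyl)-1H-1,2,3-triazol-4-yl in place of ethynyl on a saturated chain carbon bound to an oxygen next to a carbonyl group. The closest measured step is an at least 3.2-fold higher number from compound 2 to compound 3 (0.51 log units; beyond the scatter), where another fluorophenyl-bearing triazole replaced the same ethynyl and the number rose out of range; an at least 5.2-fold higher number from compound 1 to compound 3 (0.72 log units; beyond the scatter) points the same way. A rise beyond the scatter in this assay is therefore expected, with a real chance of another limit. Compound 4 is estimated at 120000 nM (range 50000 nM to 300000 nM), a step of a 2.6-fold higher number from compound 2 to compound 4 (0.42 log units; beyond the scatter).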

Compound 4, half-maximal inhibitory concentration: > 150000 nM
Compound 4 was reported as a limit (the forecaster's own chance of this, stated with the estimate: 45%); middle value at least 1.2-fold (0.09 log units) away from the limit.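

In this assay the 2-fluorophenyl triazole gives no readable number either, and compound 4 stands only at a limit, > 150000 nM. The change gives an at least 3.2-fold higher number from compound 2 to compound 4 (0.51 log units; beyond the scatter) and an at least 5.2-fold higher number from compound 1 to compound 4 (0.72 log units; beyond the scatter), so the loss seen with 4-fluorophenyl is not confined to that one fluorophenyl isomer. The step between the two fluorophenyl analogues cannot be read, since both values are limits: the limit of > 150000 nM in this assay, at which 2 of the 4 values shown sit.

On these data alone, whether the number of compound 1 depends on the hydroxyl group itself or on its placement remains open. A 4-hydroxyphenyl or 3-aminophenyl group on the triazole would address this.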